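The source may report more compounds than this note shows. Statements on the series, on what has been measured and on what is new or still open speak of the compounds shown alone.

Values measured in a physicochemical assay for metabolic stability, read by HPLC (a lower number here means that the compound disappears faster, a higher number that the compound lasts longer), stand as follows:

- compound 1 `Cc1ccc(OP(=O)(O)OC[C@H]2O[C@@H](n3cc(C)c(=O)[nH]c3=O)C[C@@H]2N=[N+]=[N-])cn1` gives 28.9 h
- compound 2 `Cc1cn([C@H]2C[C@H](N=[N+]=[N-])[C@@H](COP(=O)(O)Oc3ccc(C#N)cc3)O2)c(=O)[nH]c1=O` gives 7.08 h
- compound 3 `Nc1ncnc2c1ncn2[C@H]1CC[C@@H](COP(=O)(O)Oc2ccccc2)O1` gives 36.1 h

Compound 1 and compound 3 lie within the scatter of each other, and compound 2 lies clearly lower than both. Compound 4 `Cc1ncccc1OP(=O)(O)OC[C@H]1O[C@@H](n2cc(C)c(=O)[nH]c2=O)C[C@@H]1N=[N+]=[N-]` has not yet been measured. It keeps the core of compound 1 and differs only in the group on an oxygen whose other neighbour is phosphorus: 2-methylpyridin-3-yl in place of 6-methylpyridin-3-yl on an oxygen.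

Going by the values given here, only one measured step touches that place. It is a 4.1-fold lower number from compound 1 to compound 2 (0.61 log units; beyond the scatter), a modest step that replaced the whole 6-methylpyridin-3-yl group with 4-cyanophenyl. Among the compounds with values here, that step shows that the group on this oxygen can shift the half-life, but it says little about a change that keeps the same atoms joined differently, and the data hold no direct precedent. In this assay the expected result is a 1.2-fold lower number from compound 1 to compound 4 (0.06 log units; within the scatter) and thus no change beyond the scatter, though the uncertainty is wide. For compound 4 the estimated half-life is 25 h, with an expected range from 9 h to 60 h.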

Compound 4, half-life: 15.8 h
The estimate for compound 4 lay 1.6-fold (0.20 log units) above the measured number; the measured number falls inside the stated range.
By their numbers in this assay, from the lowest: compound 2; then compounds 4, 1 and 3 (each within the scatter of the next, the first and the last beyond it).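

In this assay the two methylpyridinyl groups on an oxygen whose other neighbour is phosphorus can be compared directly, and the exchange of 6-methylpyridin-3-yl for 2-methylpyridin-3-yl gives a 1.8-fold lower number from compound 1 to compound 4 (0.26 log units; within the scatter) and so leaves the same atoms, joined differently, without a change that can be told from the scatter. The step of a 2.2-fold higher number from compound 2 to compound 4 (0.35 log units; beyond the scatter) shows that a second methylpyridinyl group, and not only the first, stands clear of 4-cyanophenyl at this place. Nothing available here explains these numbers.

The compounds shown leave open how an unsubstituted pyridin-3-yl or a methoxy group on the pyridine would read at this oxygen on the core of compound 1. They also leave open whether a plain phenyl on that same core would fall with compound 2 or with compound 1 and compound 4.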